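The source may report more compounds than this note shows. Statements on the series, on what has been measured and on what is new or still open speak of the compounds shown alone.

Compound 3 `CCCCCCc1cn(C(c2ccccc2)c2cc3cc(Br)ccc3nc2OC)nn1` is the point of departure. Going by the values given here, in an ADME assay on PC-3 cells (Homo sapiens) for cytotoxicity, read by sulforhodamine B assay, with a stated time of 48 h, tested at 10 uM (a higher number here means more inhibition at the concentration tested (going by the name of the read-out), a lower number less inhibition), compound 3 gives 2.32%, the lowest of the three numbers measured so far, though not by much: compound 1 `COc1nc2ccc(Br)cc2cc1C(c1ccccc1)n1cc(-c2ccc(Br)cc2)nn1` gives 7.43%, and the step of a number 5.1 percentage points lower from compound 1 to compound 3 (within the scatter) lies within the scatter, while compound 2 `COc1nc2ccc(Br)cc2cc1C(c1ccccc1)n1cc(-c2cccc(F)c2)nn1` gives 14.6%, and the step of a number 12.3 percentage points lower from compound 2 to compound 3 (beyond the scatter) lies beyond it. The next compound, compound 4 `COc1nc2ccc(Br)cc2cc1C(c1ccccc1)n1cc(CCO)nn1`, differs from compound 3 by hydroxy in place of butyl on a saturated chain carbon, two bonds along the chain from an aromatic carbon. Every measured step in this set changes the group on that same aromatic carbon: a number 7.2 percentage points higher from compound 1 to compound 2 (within the scatter), a number 5.1 percentage points lower from compound 1 to compound 3 (within the scatter) and a number 12.3 percentage points lower from compound 2 to compound 3 (beyond the scatter), so swapping one group for another there has moved the read-out by at most a modest amount, and none of those swaps introduced a hydroxy. On that basis only a small step is expected, a number 2.7 percentage points higher from compound 3 to compound 4 (within the scatter), in no sure direction. Compound 4 is therefore estimated at 5% in this assay, with a range from -6% to 18%.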

Compound 4, a percentage reported as inhibition, at one concentration (the size of the read-out at that concentration, not a potency): 15.5%
Compound 4: middle estimate off by 10.5 percentage points, on the low side, and the stated range covers the measured number.
By their numbers in this assay, from the lowest: compounds 3, 1, 2 and 4 (each within the scatter of the next, the first and the last beyond it).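

In this assay, going by these compounds alone, hydroxy in place of butyl on a saturated chain carbon, two bonds along the chain from an aromatic carbon, gives a number 13.2 percentage points higher from compound 3 to compound 4 (beyond the scatter), so this is the first step in the set to bring in a hydroxy, and it moves the read-out beyond the scatter. Set against the two aryl groups, 2-hydroxyethyl gives a number 0.9 percentage points higher from compound 2 to compound 4 (within the scatter) and a number 8.1 percentage points higher from compound 1 to compound 4 (within the scatter), so this short chain cannot be told apart from 3-fluorophenyl or 4-bromophenyl, while hexyl is separated from 2-hydroxyethyl and 3-fluorophenyl but not from 4-bromophenyl. Nothing available speaks to the reason for the step.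

The compounds shown leave open whether the shorter chain or the hydroxy carries the step, which a plain ethyl group on the same aromatic carbon would help to separate. They also leave open whether a 2-aminoethyl group or a carboxylic acid on a short chain would read like 2-hydroxyethyl.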